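Moving the trifluoromethyl group around the pendant phenyl ring

A few compounds are considered here, and "the series" means these few. Any claim that something is new, unique, unknown or untested is made for them only; others in the source may bear on it.

Two close relatives of compound 3 have already been tested. Compound 1 `CC1(C)CCC(CN2CCN(c3ccc(C(=O)NS(=O)(=O)c4ccc(NCC5CCOCC5)c([N+](=O)[O-])c4)c(Oc4cnc5[nH]ccc5c4)c3)CC2)=C(c2ccc(C(F)(F)F)cc2)C1` gives 1.5 nM in an assay on isolated protein for displacement of a labelled ligand from Apoptosis regulator Bcl-2 (Homo sapiens), with a stated time of 15 min (on this read-out higher numbers stand for weaker inhibition and lower numbers for stronger inhibition), while compound 2 `COc1ccc(C2=C(CN3CCN(c4ccc(C(=O)NS(=O)(=O)c5ccc(NCC6CCOCC6)c([N+](=O)[O-])c5)c(Oc5cnc6[nH]ccc6c5)c4)CC3)CCC(C)(C)C2)cc1` gives 3.8 nM in this assay. Among the measured compounds shown here, compound 2 thus stands at the higher of the two numbers, the only recorded step being a 2.5-fold higher number from compound 1 to compound 2 (0.40 log units; beyond the scatter). Compound 3 `CC1(C)CCC(CN2CCN(c3ccc(C(=O)NS(=O)(=O)c4ccc(NCC5CCOCC5)c([N+](=O)[O-])c4)c(Oc4cnc5[nH]ccc5c4)c3)CC2)=C(c2ccccc2C(F)(F)F)C1` differs from compound 2 by 2-(trifluoromethyl)phenyl in place of 4-methoxyphenyl on a double-bonded ring carbon. The measured step bears on this change only in part: it shows that a trifluoromethyl group on that phenyl ring went with a lower number than methoxy, but in compound 1 the group sits in a different position, so the size of that effect in the new position cannot be read from the numbers at hand. Compound 3 is therefore expected to move modestly toward a lower number, a 1.5-fold lower number from compound 2 to compound 3 (0.18 log units; within the scatter), giving an estimate of 2.5 nM with a range from 0.8 nM to 8 nM.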

Compound 3, half-maximal inhibitory concentration: 1.7 nM
Estimate against measurement, compound 3: 1.5-fold (0.17 log units) above, and the stated range covers the measured number.
By their numbers in this assay, from the lowest: compounds 1 and 3 (each within the scatter of the next); then compound 2.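

Replacing 4-methoxyphenyl with 2-(trifluoromethyl)phenyl on the double-bonded ring carbon gave a 2.2-fold lower number from compound 2 to compound 3 (0.35 log units; beyond the scatter) in this assay, so a trifluoromethyl group in this new place on the phenyl ring also goes with a lower number than the methoxy group of compound 2. Moving the trifluoromethyl group on that ring gave a 1.1-fold higher number from compound 1 to compound 3 (0.05 log units; within the scatter), so the 2-(trifluoromethyl)phenyl and 4-(trifluoromethyl)phenyl groups cannot be told apart in this assay. No evidence at hand accounts for these numbers.

Still open, going by these compounds, is whether the methoxy group would keep its number if moved around the phenyl ring as the trifluoromethyl group was. The compounds shown also leave open how an amine or a carboxylic acid on that ring would compare.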